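Chlorophenyl tetrazole ethers: meta versus para placement

A few compounds are considered here, and "the series" means these few. Any claim that something is new, unique, unknown or untested is made for them only; others in the source may bear on it.

Measured so far:
- compound 1, `CCCCCCCCc1ccc(OCC(=O)Cn2nnc(-c3ccc(Cl)cc3)n2)cc1`: 35 nM
- compound 2, `CCCCCCCCc1ccc(OCC(=O)Cn2nnc(-c3cccc(Cl)c3)n2)cc1`: 24 nM
- compound 3, `CCCCCCCCc1ccc(OCC(=O)Cn2nnnc2-c2ccc(Cl)cc2)cc1`: 130 nM

In an assay on microsomes from brain for inhibition of Fatty-acid amide hydrolase 1 (Rattus norvegicus), read by fluorescence and HPLC, with a stated time of 60 min (on this read-out lower numbers stand for stronger inhibition and higher numbers for weaker inhibition), compound 1 gives 35 nM, and compound 2 gives 24 nM. The change between them is 3-chlorophenyl in place of 4-chlorophenyl on an aromatic carbon, with a 1.5-fold lower number from compound 1 to compound 2 (0.16 log units; within the scatter). Compound 3 gives 130 nM, the highest number of the three; the difference between the core of compound 3 and the core of compound 1 is not broken down here.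

Compound 4, `CCCCCCCCc1ccc(OCC(=O)Cn2nnnc2-c2cccc(Cl)c2)cc1`, is not yet measured. It differs from compound 3 by 3-chlorophenyl in place of 4-chlorophenyl on an aromatic carbon, the same kind of change as from compound 1 to compound 2, though the place differs: here the carbon is next to the ring atom that bears a large group, there it was two ring bonds from it. Because a 1.5-fold lower number from compound 1 to compound 2 (0.16 log units; within the scatter) was small, the step is expected to stay small too, a 1.4-fold lower number from compound 3 to compound 4 (0.16 log units; within the scatter). Compound 4 is therefore expected to give about 90 nM, likely between 40 nM and 250 nM.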

Compound 4, half-maximal inhibitory concentration: 360 nM
Compound 4: the middle estimate sits 4.0-fold (0.60 log units) below what was measured; the whole stated range lies below it.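

In this assay, 3-chlorophenyl in place of 4-chlorophenyl gives a 2.8-fold higher number from compound 3 to compound 4 (0.44 log units; beyond the scatter). The change therefore does not carry over as a fixed step between these two cores: the same change on two cores in this assay, a 1.5-fold lower number (0.16 log units; within the scatter) from compound 1 to compound 2 and a 2.8-fold higher number (0.44 log units; beyond the scatter) from compound 3 to compound 4, 4.0-fold (0.61 log units) apart, beyond the scatter of two such steps

This rests on a single pair per core: it shows that the outcome of the change differs between these two cores, but not why it differs or how the change would behave on any further core.

Still open, as far as these compounds go, is whether a methoxy group or a nitrile in place of the chlorine would show the same split between the two cores. Also open, from the compounds shown here alone, is whether that split would persist if a shorter chain replaced the octyl chain.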